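The compounds below may be only part of what the source reports. "The series", "measured", "known", "first", "only" and "open" are said of these compounds alone.

Measured so far in an assay for inhibition of 6-phosphofructo-2-kinase/fructose-2,6-bisphosphatase 3 (Homo sapiens), read by ADP-Glo, with a stated time of 2 h; a lower number here means a stronger inhibitor, a higher number a weaker inhibitor:
compound 1 `CN1CCC(NS(=O)(=O)c2ccccc2Nc2cc(-c3ccc4ccn(C)c4c3)c3nccnc3c2)C1` gives 33 nM;
compound 2 `CN(Cc1cncnc1)S(=O)(=O)c1ccccc1Nc1cc(-c2ccc3ccn(C)c3c2)c2nccnc2c1` gives 62 nM;
compound 3 `CC(=O)N1CCCC(NC(=O)c2ccncc2Nc2cc(-c3ccc4ccn(C)c4c3)c3nccnc3c2)C1` gives 11 nM.

Compound 3 stands lowest of the three numbers, and its gaps to compound 1 and to compound 2 both lie beyond the usual scatter. Compound 4 `CN1CCC(N(C)C(=O)c2ccncc2Nc2cc(-c3ccc4ccn(C)c4c3)c3nccnc3c2)C1` differs from compound 3 in one place: methyl(1-methylpyrrolidin-3-yl)amino in place of (1-acetylpiperidin-3-yl)amino on a carbonyl carbon. Among the compounds with values here, the only measured step, a 1.9-fold higher number from compound 1 to compound 2 (0.27 log units; within the scatter), exchanges an amine on a sulfonyl sulfur rather than on a carbonyl carbon and stays within the scatter; no measured step touches the carbonyl carbon of compound 3. The step of a 1.8-fold higher number from compound 3 to compound 4 (0.26 log units; within the scatter) is therefore expected to be small, with no clear direction. Compound 4 is estimated at 20 nM in this assay, within 6 nM to 65 nM.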

Compound 4, half-maximal inhibitory concentration: 176 nM
Compound 4: the middle estimate sits 8.8-fold (0.94 log units) below what was measured; measured number above the stated range.
By their numbers in this assay, from the lowest: compound 3; then compounds 1 and 2 (each within the scatter of the next); then compound 4.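

In this assay, within the data shown here, the amine on a carbonyl carbon proves to matter greatly, with a 16-fold higher number from compound 3 to compound 4 (1.20 log units; beyond the scatter) as a large step, unlike the one earlier exchange, on a sulfonyl sulfur. The change alters several things at once: ring size, the acetyl group and the amide hydrogen, which is lost. No measured evidence bears on the cause of this step.

Which of these differences carries the loss remains open. A piperidine with a free amine in place of the acetyl, or a pyrrolidine that keeps the amide hydrogen, could begin to separate them.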